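A Piperazin-1-yl Swap on Compound 2

A few compounds are considered here, and "the series" means these few. Any claim that something is new, unique, unknown or untested is made for them only; others in the source may bear on it.

Of the compounds shown here, two have so far been measured in a functional assay on a cell-free system (Platelet, plasma, Homo sapiens) for inhibition; on this read-out lower numbers stand for stronger inhibition and higher numbers for weaker inhibition. Compound 1 `O=C(O)CCN1Cc2ccc(NC(=O)c3ccc(N4CCNCC4)cc3)cc2C1=O` gives 540 nM, while compound 2 `CC(CC(=O)O)N1Cc2ccc(NC(=O)c3ccc(C4CCNCC4)cc3)cc2C1=O` gives 6200 nM, the higher of the two numbers and beyond the scatter from compound 1. Compound 3 `CC(CC(=O)O)N1Cc2ccc(NC(=O)c3ccc(N4CCNCC4)cc3)cc2C1=O` differs from compound 2 by piperazin-1-yl in place of piperidin-4-yl on an aromatic carbon. Going by the values given here, compound 1 also carries piperazin-1-yl, yet it differs from compound 2 in another place too, so no step for this change alone is known. In this assay compound 3 is expected to show a 4.1-fold lower number from compound 2 to compound 3 (0.62 log units; beyond the scatter), a step downward. The estimate for compound 3 is 1500 nM, with a range from 400 nM to 6000 nM.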

Compound 3, half-maximal inhibitory concentration: 3740 nM
For compound 3 the middle estimate is 2.5-fold (0.40 log units) below the measured one; low and high end bracket the measured number.
By their numbers in this assay, from the lowest: compound 1; then compounds 3 and 2 (each within the scatter of the next).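

In this assay, piperazin-1-yl in place of piperidin-4-yl on an aromatic carbon gives a 1.7-fold lower number from compound 2 to compound 3 (0.22 log units; within the scatter), so with the methyl present on the chain this swap does not separate the two compounds. The methyl itself, now read alone, gives a 6.9-fold higher number from compound 1 to compound 3 (0.84 log units; beyond the scatter), and of the two steps only this one lies beyond the scatter. Nothing available explains either step. Still open, on these data alone, is how piperidin-4-yl reads on the chain without the methyl, and how an ethyl on that chain carbon would read.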